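Naphthyl to chlorobenzyl on the thiadiazole side chain

The source may hold more compounds than are shown below. What is called first, only, known or untested is meant among the compounds shown, and "the series" means these compounds.

Compound 1 `COc1ccc(S(=O)(=O)Oc2ccccc2/C=C(\C#N)C(=O)Nc2nnc(Cc3cccc4ccccc34)s2)cc1` stands highest of the two compounds measured in an ADME assay on HEK-293T cells (Homo sapiens) for inhibition, read by CCK-8 assay, with a stated time of 48 h, tested at 20 uM (a higher number here means more inhibition of growth at the concentration tested, a lower number less inhibition of growth), giving 29%. Going by the values given here, its nearest neighbour, compound 2 `N#C/C(=C\c1ccccc1OS(=O)(=O)c1ccc(F)cc1)C(=O)Nc1nnc(Cc2cccc3ccccc23)s1`, gives 15% in this assay; the single step available, a number 14 percentage points lower from compound 1 to compound 2 (beyond the scatter), concerns fluoro in place of methoxy on an aromatic carbon. Compound 3 `COc1ccc(S(=O)(=O)Oc2ccccc2/C=C(\C#N)C(=O)Nc2nnc(Cc3ccc(Cl)cc3)s2)cc1` differs from compound 1 elsewhere: 4-chlorophenyl in place of naphthalen-1-yl on a saturated chain carbon bound to an aromatic carbon. No measured step touches this position, so the direction is open; the one step shown is modest, and a change of similar or smaller size is expected here. Compound 3 is therefore estimated at 22%, between 5% and 40%, an expected step of a number 7 percentage points lower from compound 1 to compound 3 (within the scatter).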

Compound 3, percent growth inhibition at one concentration: 26%
The estimate for compound 3 lay 4 percentage points below the measured number; the measured number falls inside the stated range.
By their numbers in this assay, from the lowest: compound 2; then compounds 3 and 1 (each within the scatter of the next).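

At the saturated chain carbon bound to an aromatic carbon, 4-chlorophenyl in place of naphthalen-1-yl gives a number 3 percentage points lower from compound 1 to compound 3 (within the scatter) in this assay. This position therefore accepts one six-membered aromatic ring with chlorine in place of two such rings without a difference that stands out from the scatter. No measurement available here bears on the reason for this.

As far as these compounds go, whether the chlorine itself matters remains open, as does how an amine, a carboxylic acid or a longer chain would read at this position. Also open, from the compounds shown here alone, is whether fluoro in place of methoxy would give a similar step with 4-chlorophenyl present.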